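Swapping the Aryl Group on a Triazole Acetamide

A few compounds are considered here, and "the series" means these few. Any claim that something is new, unique, unknown or untested is made for them only; others in the source may bear on it.

Of the compounds shown here, three built on a shared core have been measured in a functional assay on BMDM cells (Mus musculus, strain C57BL/6) for inhibition, with a stated time of 2 days; a higher number here means a weaker inhibitor, a lower number a stronger inhibitor. Compound 1 `COc1ccc(-c2cn(CC(=O)Nc3nc4ccccc4s3)nn2)cc1` gives 1330 nM. Compound 2 `Cc1csc(NC(=O)Cn2cc(-c3ccccc3Cl)nn2)n1` gives 1240 nM, the second highest of the three numbers; its nearest neighbour is compound 1, within the scatter, and its furthest is compound 3 `O=C(Cn1cc(-c2ccccc2Cl)nn1)Nc1nccs1`, which gives 60 nM. Within the data shown here, the only step between compounds differing in one place is a 21-fold lower number from compound 2 to compound 3 (1.32 log units; beyond the scatter), a hydrogen in place of methyl on an aromatic carbon.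

The unmeasured compound 4 `Cc1csc(NC(=O)Cn2cc(-c3ccncc3)nn2)n1` differs from compound 2 elsewhere: pyridin-4-yl in place of 2-chlorophenyl on an aromatic carbon. Among the measured compounds shown here, no measured step touches this position: the step from compound 2 to compound 3 concerns another part of the molecule, and compound 1 differs from compound 2 in two places at once, so it offers no single step. With nothing pointing in either direction, compound 4 is expected to land within the scatter of compound 2, a 1.2-fold higher number from compound 2 to compound 4 (0.08 log units; within the scatter). Compound 4 is therefore estimated at 1500 nM, with a range from 400 nM to 6000 nM.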

Compound 4, half-maximal inhibitory concentration: 100 nM
The estimate for compound 4 lay 15-fold (1.18 log units) above the measured number, outside the stated range (below it).
By their numbers in this assay, from the lowest: compounds 3 and 4 (each within the scatter of the next); then compounds 2 and 1 (each within the scatter of the next).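

In this assay, the aromatic carbon of the five-membered aromatic ring with 3 nitrogen proves sensitive to its substituent: pyridin-4-yl in place of 2-chlorophenyl gives a 12-fold lower number from compound 2 to compound 4 (1.09 log units; beyond the scatter). Among these compounds, this is the first single step at this position, and it shows that compound 2 can also be moved to a much lower number by a change away from the methyl site, as already seen in a 21-fold lower number from compound 2 to compound 3 (1.32 log units; beyond the scatter). The data at hand offer nothing that explains the step.

The compounds shown do not separate the loss of the chlorine from the entry of the ring nitrogen, which a plain phenyl or a pyridin-3-yl group at this carbon could address. They also leave open whether pyridin-4-yl would lower the number further on the core of compound 3, which lacks the methyl.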